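Swapping one halogenated ring for another at the chain end

The source may hold more compounds than are shown below. What is called first, only, known or untested is meant among the compounds shown, and "the series" means these compounds.

Measured compounds:
- compound 1, `COc1cc(OC)c(OC)cc1/C=C/COC(=O)/C=C/c1cccc(Br)c1`: 100%
- compound 2, `COc1cc(OC)c(OC)cc1/C=C/COC(=O)/C=C/c1ccc(OC)c(OC)c1OC`: 100%

Both measured compounds share the same core and differ only in the aromatic ring at the far end of the unsaturated ester. In a functional assay on the whole organism (strain Kunming) with Mus musculus as the target, with a stated time of 0.5 h, at a dose of 100 mg/kg by the intraperitoneal route (a lower number here means a stronger effect, a higher number a weaker effect of the compound at the dose given), compound 1 gives 100%. In this assay compound 2 gives 100%. Compound 1 stands level with compound 2 at the digits shown, so on these numbers the two are indistinguishable, and nothing can be said about which of them is the stronger.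

Compound 3, `COc1cc(OC)c(OC)cc1/C=C/COC(=O)/C=C/c1ccc(Cl)cc1`, is not yet measured in this assay. It differs from compound 1 in one place: 4-chlorophenyl in place of 3-bromophenyl on a double-bonded chain carbon bound to a double-bonded chain carbon. The change keeps a halogen-bearing ring of the same size at the same position on the chain.

Within the data shown here, with no step between two measured compounds to lean on, and with compound 1 and compound 2 giving the same reading despite quite different rings, no shift beyond the scatter is expected for the step of no change at the digits printed from compound 1 to compound 3 (within the scatter). Compound 3 is therefore expected to give about 100%, most likely between 85% and 100%.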

Compound 3, a percentage reported as activity, at one dose (the size of the read-out at that dose, not a potency): 100%
For compound 3 middle estimate and measured number coincide at the digits printed; the measured number falls inside the stated range.
By their numbers in this assay, from the lowest: compounds 1, 2 and 3 (each within the scatter of the next).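

In this assay, putting 4-chlorophenyl in place of 3-bromophenyl on a double-bonded chain carbon bound to a double-bonded chain carbon gives no change at the digits printed from compound 1 to compound 3 (within the scatter). Among these compounds, this is the first measured step at this position, and it shows that this exchange of one halogen-bearing ring for another leaves the reading where it was. The names of the two groups show that the halogen and its numbered place on the ring both change in this one step, so a shift from one change could in principle be offset by the other, and this single step cannot separate them.

As far as these compounds go, it remains open whether a ring carrying an amine or a carboxylic acid, or a longer chain between the ring and the ester, would move the reading in this assay away from the level of compound 3 at 100%. No other evidence is available to explain this result.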